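The source may hold more compounds than are shown below. What is called first, only, known or untested is meant among the compounds shown, and "the series" means these compounds.

Measured compounds:
compound 1, `O=S(=O)(NCCCCNCc1ccc(Br)cc1)c1cc(C(F)(F)F)cc(C(F)(F)F)c1`, with 1900 nM in a functional assay on Capan-2 cells (Homo sapiens) for inhibition, read by MTT assay, with a stated time of 72 h; on this read-out higher numbers stand for weaker inhibition of growth and lower numbers for stronger inhibition of growth
compound 2, `O=S(=O)(NCCCNCc1ccc(Cl)c(Cl)c1)c1cc(C(F)(F)F)cc(C(F)(F)F)c1`, with 1800 nM
compound 3, `O=S(=O)(NCCCNCc1ccc(-c2ccccc2)cc1)c1cc(C(F)(F)F)cc(C(F)(F)F)c1`, with 2200 nM

Compound 3 gives the highest of these three numbers in this assay, but the gaps that separate it from compound 1 and from compound 2 both stay within the scatter, so on these numbers the three compounds cannot be told apart.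

The unmeasured compound 4, `O=S(=O)(NCCCNCc1ccc(Cl)cc1)c1cc(C(F)(F)F)cc(C(F)(F)F)c1`, differs from compound 3 in one place: chloro in place of phenyl on an aromatic carbon. Among the measured compounds shown here, the only measured step that bears on such a swap is a 1.1-fold lower number from compound 1 to compound 2 (0.02 log units; within the scatter): there, one substituted benzyl group gave way to another substituted benzyl group on the same chain region, and the number hardly moved. Compound 4 carries a benzyl group bearing a single chloro group, and compound 1, whose benzyl group bears a single bromo group, sits in the same narrow band as compound 2 and compound 3. From this, the step of a 1.2-fold lower number from compound 3 to compound 4 (0.06 log units; within the scatter) is expected to be small, with no direction that rises beyond the scatter. Compound 4 is therefore estimated at 1900 nM, with a range from 900 nM to 4000 nM.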

Compound 4, concentration for 50% growth inhibition: 2700 nM
For compound 4 the middle estimate is 1.4-fold (0.15 log units) below the measured one, within the range that was stated.
By their numbers in this assay, from the lowest: compounds 2, 1, 3 and 4 (each within the scatter of the next).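

In this assay, chloro in place of phenyl on the aromatic carbon para to a large group gives a 1.2-fold higher number from compound 3 to compound 4 (0.09 log units; within the scatter), so even losing a whole six-membered aromatic ring at this position leaves a change that cannot be told from repeat-measurement noise. Hydrogen in place of the second chloro on the ring gives a 1.5-fold higher number from compound 2 to compound 4 (0.18 log units; within the scatter), and the pair that differs in its benzyl-bearing stretch of chain, with bromo giving way to chloro, gives a 1.4-fold higher number from compound 1 to compound 4 (0.15 log units; within the scatter), so these swaps also stay inside the scatter and the four compounds form a single flat band with no order among them. Nothing available explains why such different groups leave the number in that band.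

From the compounds shown here alone, all the groups seen on this ring so far are halogens or phenyl, so it remains open whether a carboxylic acid or an amine on the same aromatic carbon would move the number beyond the scatter. Also open, going by these compounds, is whether a longer chain between the sulfonamide nitrogen and the benzyl amine, or a benzyl group replaced by a simple methyl, would break the flat pattern seen here.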